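The source may report more compounds than this note shows. Statements on the series, on what has been measured and on what is new or still open speak of the compounds shown alone.

Measured compounds in a functional assay on MKN-45 cells (Homo sapiens) for cytotoxicity, read by MTT assay, with a stated time of 72 h; a lower number here means a stronger inhibitor, a higher number a weaker inhibitor:
- compound 1 `COc1ccc(-c2cc(C(=O)Nc3ccc(Oc4ccnc5cc(OCCCN6CCCCC6)c(OC)cc45)c(F)c3)c3ccccc3n2)cc1`: 210 nM
- compound 2 `COc1cc2c(Oc3ccc(NC(=O)c4cc(-c5ccc(Cl)c(Cl)c5)nc5ccccc45)cc3F)ccnc2cc1OCCCN1CCCCC1`: 730 nM
- compound 3 `COc1cc2c(Oc3ccc(NC(=O)c4cc(-c5ccc(Cl)c(Cl)c5)nc5ccccc45)cc3F)ccnc2cc1OCCCN1CCCC1`: 170 nM

Compound 3 gives the lowest number of the three; compound 1 sits within the scatter of it, so the two cannot be ordered, while compound 2 lies clearly higher. Compound 3 and compound 2 share the 3,4-dichlorophenyl group and differ only in the amine at the end of the chain. Going by the values given here, that step a 4.3-fold lower number from compound 2 to compound 3 (0.63 log units; beyond the scatter) is the only one among the measured changes that lowers the number beyond the scatter.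

Compound 4 `COc1cc2c(Oc3ccc(NC(=O)c4cc(-c5ccc(C)cc5)nc5ccccc45)cc3F)ccnc2cc1OCCCN1CCCC1` keeps the pyrrolidin-1-yl chain of compound 3 and changes the aryl group: 4-methylphenyl in place of 3,4-dichlorophenyl on an aromatic carbon. Among the compounds with values here, the only measured step that touches this position is the exchange of 4-methoxyphenyl for 3,4-dichlorophenyl, a 3.5-fold higher number from compound 1 to compound 2 (0.54 log units; beyond the scatter), which raised the number modestly. Compound 4 moves back from the dichlorophenyl to a single para-substituted phenyl, though with methyl rather than methoxy, so the earlier step is read as a rough guide only. A modest lowering, or a result within the scatter of compound 3, is expected in this assay.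

The step from compound 3 to compound 4 is therefore estimated as a 1.7-fold lower number from compound 3 to compound 4 (0.23 log units; within the scatter). For compound 4 the expected value is 100 nM, with a range from 40 nM to 300 nM.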

Compound 4, half-maximal inhibitory concentration: 300 nM
Beside the measured number, compound 4's estimate is 3.0-fold (0.48 log units) below it; the range from low to high includes it.
By their numbers in this assay, from the lowest: compounds 3, 1 and 4 (each within the scatter of the next); then compound 2.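

With the pyrrolidin-1-yl chain held fixed in this assay, the exchange of 3,4-dichlorophenyl for 4-methylphenyl, on the aromatic carbon next to the ring nitrogen, gives a 1.8-fold higher number from compound 3 to compound 4 (0.25 log units; within the scatter) and leaves the two compounds unordered, so the two aryl groups cannot be told apart here. Going by these compounds alone, the only earlier step at this position, a 3.5-fold higher number from compound 1 to compound 2 (0.54 log units; beyond the scatter), was read on the piperidin-1-yl chain with 4-methoxyphenyl as the other partner, and it did resolve a difference; the new pair shows that a change of aryl group at this carbon need not do so, though the two steps differ in both the chain and the single-substituent aryl group. No measurement shown here explains the contrast between the two steps.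

Still open, as far as these compounds go, is whether 4-methoxyphenyl and 4-methylphenyl would separate if compared on one chain, and whether the exchange from 3,4-dichlorophenyl to 4-methylphenyl would give a step of the same size on the piperidin-1-yl chain. Also open, from the compounds shown here alone, is how an unsubstituted phenyl or a 4-fluorophenyl at this carbon, or a morpholin-4-yl group at the end of the chain, would compare.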